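This account rests on a few compounds, and the source may have more. Where it says the series, first, only, none or still open, it means among the compounds named here.

Compound 1 `COc1ccc(-c2ccc(-c3ccc(C(=N)N)o3)o2)cc1` is the stronger-looking of the two measured compounds on paper, giving 1840 nM in a functional assay on CCRF-CEM cells (Homo sapiens) for inhibition, read by sulforhodamine B assay, with a stated time of 48 h (a higher number here means a weaker inhibitor of growth, a lower number a stronger inhibitor of growth), yet compound 2 `COc1cc(OC)cc(-c2ccc(-c3ccc(C(=N)N)o3)o2)c1` gives 2720 nM in this assay, a gap that sits within the scatter, so the two cannot be ranked. Compound 3 `N=C(N)c1ccc(-c2ccc(-c3ccccc3)o2)o1` differs from compound 1 by hydrogen in place of methoxy on an aromatic carbon. For the measured compounds named here, no measured pair shows what removing this group does, so the step of a 1.2-fold higher number from compound 1 to compound 3 (0.08 log units; within the scatter) is expected to be small, with no clear direction beyond the scatter. Compound 3 is therefore expected to give about 2200 nM, plausibly between 800 nM and 6000 nM.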

Compound 3, concentration for 50% growth inhibition: 3580 nM
Estimate against measurement, compound 3: 1.6-fold (0.21 log units) below, within the range that was stated.
By their numbers in this assay, from the lowest: compounds 1, 2 and 3 (each within the scatter of the next).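

Hydrogen in place of methoxy on this aromatic carbon now has a direct measured comparison: in this assay, the swap gives a 1.9-fold higher number from compound 1 to compound 3 (0.29 log units; within the scatter). On this single pair, the methoxy at this place makes no difference that can be told from ordinary repeat variation. No supporting measurement here bears on this result.

Still open, going by these compounds, is whether another group at this place, such as an amine, a carboxylic acid or a longer chain like butoxy, would give a step beyond the scatter. Also open, on these data alone, is whether the same swap would read alike on a different core.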